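The source may hold more compounds than are shown below. What is called first, only, known or untested is meant among the compounds shown, and "the series" means these compounds.

Measured in a functional assay on MCF7 cells (Homo sapiens) for antiproliferative activity, read by MTT assay, with a stated time of 72 h; a lower number here means a stronger inhibitor, a higher number a weaker inhibitor:
Compound 1 `O=C(Nc1ccc(Nc2nccc(NC3CCCCC3)n2)cc1)Nc1ccc(Cl)c(C(F)(F)F)c1` gives 10800 nM
Compound 2 `O=C(Nc1ccc(Nc2nccc(NC3CCCC3)n2)cc1)Nc1ccc(Cl)c(C(F)(F)F)c1` gives 2330 nM
Compound 3 `CCCNc1ccnc(Nc2ccc(NC(=O)Nc3ccc(Cl)c(C(F)(F)F)c3)cc2)n1` gives 4610 nM

These three share one core and differ only in the group on a nitrogen on an aromatic ring. Compound 3 carries propyl there and cannot be told apart from compound 2, since the gap is a 2.0-fold higher number from compound 2 to compound 3 (0.30 log units; within the scatter) and no more. Compound 1 is the weakest inhibitor of the three, and the gap on that side is a 2.3-fold lower number from compound 1 to compound 3 (0.37 log units; beyond the scatter) as a modest step.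

Compound 4 `O=C(Nc1ccc(Nc2nccc(Nc3ccccc3)n2)cc1)Nc1ccc(Cl)c(C(F)(F)F)c1` has not yet been measured. It has phenyl in place of propyl on a nitrogen on an aromatic ring, so propylamino becomes anilino phenyl in place of propyl on a nitrogen on an aromatic ring and the chain gives way to an aromatic ring. Going by the values given here, no measured compound carries phenyl at this place, so the evidence is indirect. Among the compounds with values here, the three earlier swaps of this group are the only guide, and the largest of them is a 4.6-fold lower number from compound 1 to compound 2 (0.67 log units; beyond the scatter) as a modest move. They give no direction for phenyl, so no clear step is expected in this assay and a modest move either way would not surprise.

For compound 4 the expected value is 4000 nM and the estimated range runs from 1300 nM to 12000 nM as a rough span. The estimated change is a 1.2-fold lower number from compound 3 to compound 4 (0.06 log units; within the scatter) as expected here.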

Compound 4, half-maximal inhibitory concentration: > 50000 nM
Compound 4 was reported as a limit (the forecaster's own chance of this, stated with the estimate: 5%); middle value at least 12-fold (1.09 log units) from the limit.
By their numbers in this assay, from the lowest: compounds 2 and 3 (each within the scatter of the next); then compound 1. At a limit, above all of these: compound 4.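

In this assay, compound 4 is known only as a limit, not as a number: the limit of > 50000 nM in this assay, at which 1 of the 4 values shown sits.

Until now, swaps at this nitrogen had given modest steps at most, whereas the change to phenyl gives large ones, with an at least 10-fold higher number from compound 3 to compound 4 (1.03 log units; beyond the scatter) and an at least 21-fold higher number from compound 2 to compound 4 (1.33 log units; beyond the scatter); even from the cyclohexyl compound, the weakest of the earlier three, the step is an at least 4.6-fold higher number from compound 1 to compound 4 (0.66 log units; beyond the scatter). A ring as such does not set compound 4 apart, since the cyclopentyl and cyclohexyl compounds both give measured values; among the compounds shown, what is unique to compound 4 is that the ring on this nitrogen is aromatic, turning propylamino into anilino.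

Going by these compounds, it remains open whether other aromatic rings on this nitrogen, such as a pyridine ring, behave the same way, or whether a benzyl group, which holds the phenyl ring one carbon further out, or a phenyl ring carrying a methoxy or hydroxyl group would bring back a measurable value. Also open, on these data alone, is how a shorter chain such as methyl or ethyl, or a longer one such as butyl, would compare with propyl.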